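The source may hold more compounds than are shown below. What is called first, only, known or untested is meant among the compounds shown, and "the series" means these compounds.

Measured compounds:
- compound 1, `Cc1nc(S(C)(=O)=O)ccc1Oc1ncnc(OC2CCN(C(=O)OC(C)(C)C(F)(F)F)CC2)c1F`: 47.2 nM in a functional assay on isolated protein for inhibition of Glucose-dependent insulinotropic receptor (Rattus norvegicus), read by HTRF and cAMP accumulation; a lower number here means that less compound is needed, a higher number that more compound is needed for the effect
- compound 2, `CCC1(OC(=O)N2CCC(Oc3ncnc(Oc4ccc(S(C)(=O)=O)nc4C)c3F)CC2)CC1`: 333 nM in this assay
- compound 3, `Cc1nc(S(C)(=O)=O)ccc1Oc1ncnc(OC2CCN(C(=O)OC3(C(F)(F)F)CCC3)CC2)c1F`: 63.3 nM in this assay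

All three share one core and differ only in the group attached through an oxygen to the carbonyl of the ring nitrogen. Compound 3 stands second highest of the three numbers: its value sits close to that of compound 1, since a 1.3-fold higher number from compound 1 to compound 3 (0.13 log units; within the scatter), and clearly lower than compound 2, since a 5.3-fold lower number from compound 2 to compound 3 (0.72 log units; beyond the scatter). The largest step seen is a 7.1-fold higher number from compound 1 to compound 2 (0.85 log units; beyond the scatter).

Compound 4, `Cc1nc(S(C)(=O)=O)ccc1Oc1ncnc(OC2CCN(C(=O)c3noc(C(C)C)n3)CC2)c1F`, breaks with this series. Here (a group of 8 heavy atoms (5 carbon, 2 nitrogen, 1 oxygen; one five-membered aromatic ring with 3 hetero atoms) in place of a group of 9 heavy atoms (5 carbon, 1 oxygen, 3 fluorine; one four-membered non-aromatic ring of carbon only), on a carbonyl carbon). Among the compounds with values here, no measured step removes the oxygen from the carbonyl or places an aromatic ring there, so none of the three steps bears directly on this change; they only show that exchanges in this region of the molecule move the number in this assay by anything from within the scatter to a modest amount. A modest shift in either direction is therefore the most that can be expected, with no firm direction.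

Compound 4 is estimated at 110 nM in this assay, with a range from 30 nM to 450 nM. This estimate corresponds to an expected step of a 1.7-fold higher number from compound 3 to compound 4 (0.24 log units; within the scatter).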

Compound 4, half-maximal effective concentration: 176 nM
Compound 4: middle estimate off by 1.6-fold (0.20 log units), on the low side, within the range that was stated.
By their numbers in this assay, from the lowest: compounds 1 and 3 (each within the scatter of the next); then compounds 4 and 2 (each within the scatter of the next).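

Of the four compounds, only compound 4 has a ring joined directly to the carbonyl carbon, with no oxygen in between, and this assay shows that this 5-isopropyl-1,2,4-oxadiazol-3-yl group costs something against both trifluoromethyl-bearing groups: a 2.8-fold higher number from compound 3 to compound 4 (0.44 log units; beyond the scatter) and a 3.7-fold higher number from compound 1 to compound 4 (0.57 log units; beyond the scatter) both lie beyond the scatter, though only modestly. Against the 1-ethylcyclopropyl group, which has no fluorine, the picture differs: a 1.9-fold lower number from compound 2 to compound 4 (0.28 log units; within the scatter) lies within the scatter, so compound 2 and compound 4 cannot be told apart, and the position accepts an aromatic ring with only a modest change in the number. Nothing measured here gives a reason for these differences.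

Open is whether the gap to compound 1 and compound 3 belongs to the aromatic ring itself or to the isopropyl group it carries, since only one such ring is shown. A tert-butyl or cyclopropyl group in place of that isopropyl, or an amine on the carbonyl carbon in place of the ring, could help to separate these possibilities.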